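The source may hold more compounds than are shown below. What is called first, only, known or untested is meant among the compounds shown, and "the series" means these compounds.

Measured so far in a functional assay on UO-31 cells (Homo sapiens) for inhibition, read by sulforhodamine B assay, with a stated time of 48 h; a higher number here means a weaker inhibitor of growth, a lower number a stronger inhibitor of growth:
compound 1, `Nc1cc(N)c2nc(-c3ccccc3)c(Oc3ccc(Cl)c(Cl)c3)nc2c1`, < 100000 nM
compound 2, `CCOC(=O)[C@H](CCC(=O)O)NC(=O)c1ccc(CNc2nc3cc(N)cc(N)c3nc2-c2ccccc2)cc1`, < 100000 nM
compound 3, `CCOC(=O)[C@H](CCC(=O)O)NC(=O)c1ccc(Sc2nc3cc(N)cc(N)c3nc2-c2ccccc2)cc1`, < 100000 nM.

For compound 1 the value in this assay is a limit of the assay, not a number. For compound 2 the value is likewise a limit. For compound 3 it is a limit as well. The three compounds therefore give no step between them that could be sized; all that is shown is the limit of < 100000 nM in this assay, at which 3 of the 3 values shown sit.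

Compound 4, `Nc1cc(N)c2nc(-c3ccccc3)c(Sc3ccc(Cl)c(Cl)c3)nc2c1`, differs from compound 1 by (3,4-dichlorophenyl)sulfanyl in place of 3,4-dichlorophenoxy on an aromatic carbon. With compound 1 standing only at a limit, the expected step that the limit leaves unreadable from compound 1 to compound 4 is none beyond the scatter. Compound 4 is therefore estimated at 50000 nM, within 5000 nM to 100000 nM, most likely again reported as a limit.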

Compound 4, concentration for total growth inhibition: < 100000 nM
Compound 4: a limit, no number (the forecaster's own chance of this, stated with the estimate: 70%); the middle value lies beyond the limit too.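

Compound 4, like compound 1, stands only at a limit in this assay, so no step between compound 1 and compound 4 can be read: the limit of < 100000 nM in this assay, at which 4 of the 4 values shown sit.

The compounds shown leave open whether (3,4-dichlorophenyl)sulfanyl and 3,4-dichlorophenoxy differ at all in this read-out, and what actual concentration any of the four compounds requires.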